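The compounds below may be only part of what the source reports. "The series", "measured", "known", "first", "only" and "open" are said of these compounds alone.

Measured in a functional assay on U-937 cells (Homo sapiens) for antiproliferative activity, read by MTT assay, with a stated time of 24 h; a lower number here means a stronger inhibitor, a higher number a weaker inhibitor:
- Compound 1 `CCCCc1oc2ccccc2c1C(=O)c1ccc(OCC(=O)NC(C)C)cc1`: 17500 nM
- Compound 2 `CCCCNC(=O)COc1ccc(C(=O)c2c(CCCC)oc3ccccc23)cc1`: 22800 nM
- Compound 3 `CCCCc1oc2ccccc2c1C(=O)c1cc(I)c(OCCCN2CCN(C)CC2)c(I)c1`: > 50000 nM, a limit and not a number

Compound 3 has no numerical value on this scale. For compound 3 the position is the limit of > 50000 nM in this assay, at which 1 of the 3 values shown sits.

The step of interest leads to compound 4 `CCCCc1oc2ccccc2c1C(=O)c1cc(I)c(OCCCNCc2ccccc2)c(I)c1`: benzylamino in place of 4-methylpiperazin-1-yl on a saturated chain carbon, three bonds along the chain from an oxygen on an aromatic ring. This places benzylamino in place of 4-methylpiperazin-1-yl on a saturated chain carbon, three bonds along the chain from an oxygen on an aromatic ring.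

Among the compounds with values here, the only measured step is a 1.3-fold higher number from compound 1 to compound 2 (0.11 log units; within the scatter). It concerns butyl in place of isopropyl on an amide-type nitrogen, so it bears only indirectly on this change. Within the data shown here, no measured step covers the same place, and the limit leaves the true size of any change open.

In this assay, a modest move to a lower number is the working expectation, with a return of the limit still quite possible. The nearest numerical reference points are compound 1 at 17500 nM and compound 2 at 22800 nM.

The expected step is an at least 1.6-fold lower number from compound 3 to compound 4 (0.22 log units; that floor lies within the scatter).

For compound 4 the estimated value is 30000 nM, with an expected range from 12000 nM to 70000 nM.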

Compound 4, half-maximal inhibitory concentration: 2300 nM
The estimate for compound 4 lay 13-fold (1.12 log units) above the measured number; the whole stated range lies above it.
By their numbers in this assay, from the lowest: compound 4; then compounds 1 and 2 (each within the scatter of the next). At a limit, above all of these: compound 3.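

In this assay, benzylamino in place of 4-methylpiperazin-1-yl, on a saturated chain carbon three bonds along the chain from an oxygen on an aromatic ring, gives an at least 21-fold lower number from compound 3 to compound 4 (1.33 log units; beyond the scatter). The number therefore responds strongly to the group at this chain end, which the earlier step at an amide-type nitrogen, in another place, could not show. The step is only a floor because compound 3 stands at a limit and not at a number: the limit of > 50000 nM in this assay, at which 1 of the 4 values shown sits.

Going by these compounds, it remains open whether the change follows the carbon-only aromatic ring of benzylamino or the hydrogen on its nitrogen; a piperidin-1-yl or an anilino group at this place would help separate the two. On these data alone, it is also open whether a longer chain carrying benzylamino would hold the number of compound 4 at 2300 nM.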